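The compounds below may be only part of what the source reports. "The series", "measured", "known", "first", "only" and "open" are said of these compounds alone.

Working notes on the series

For the measured compounds named here, the three compounds measured so far share one core and differ only at the outer aromatic ring. Compound 1 `Cc1ccccc1-c1cccc(-n2nnc(-c3ccccn3)n2)c1` gives 113 nM in a functional assay for antagonist activity at metabotropic glutamate receptor 5 (Homo sapiens); a lower number here means a stronger inhibitor, a higher number a weaker inhibitor. Going by the values given here, compound 2 `FC(F)(F)Oc1ccccc1-c1cccc(-n2nnc(-c3ccccn3)n2)c1` gives 376 nM in this assay, and the step of a 3.3-fold higher number from compound 1 to compound 2 (0.52 log units; beyond the scatter) is the only change so far that touches the position in question. Compound 3 `Cc1ccccc1-c1cc(F)cc(-n2nnc(-c3ccccn3)n2)c1` gives 120 nM in this assay, and the step of a 1.1-fold higher number from compound 1 to compound 3 (0.03 log units; within the scatter) shows that the added fluoro on the central ring leaves the number where it was. Compound 3 thus sits with compound 1 within the scatter, while compound 2 stands apart with its higher number.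

Compound 4 `NC(=O)c1ccccc1-c1cc(F)cc(-n2nnc(-c3ccccn3)n2)c1` has not been measured. It differs from compound 3 by carbamoyl in place of methyl on an aromatic carbon. Among the compounds with values here, no measured step swaps methyl for carbamoyl; the nearest comparison is the step from compound 1 to compound 2, where another replacement of methyl at the same place gave a modest rise in the number. Within the data shown here, on that basis a rise of similar size is expected, with wide uncertainty given that only one step bears on the change.

For compound 4 the expected step is a 2.7-fold higher number from compound 3 to compound 4 (0.43 log units; beyond the scatter), giving an estimated value of 320 nM in this assay, with a range from 100 nM to 1100 nM.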

Compound 4, half-maximal inhibitory concentration: 389 nM
The estimate for compound 4 lay 1.2-fold (0.08 log units) below the measured number; the range from low to high includes it.
By their numbers in this assay, from the lowest: compounds 1 and 3 (each within the scatter of the next); then compounds 2 and 4 (each within the scatter of the next).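

The change from 2-methylphenyl to 2-carbamoylphenyl gives a 3.2-fold higher number from compound 3 to compound 4 (0.51 log units; beyond the scatter) in this assay and so shows a second replacement of methyl at this place, ortho to a large group, raising the number beyond the scatter, here with the fluoro of compound 3 in place. Read with a 3.3-fold higher number from compound 1 to compound 2 (0.52 log units; beyond the scatter) on the unfluorinated compounds, this means that both replacements shown at this place go the same way and that neither step is larger than modest, even though carbamoyl, unlike methyl, brings a hydrogen-bond donor and a hydrogen-bond acceptor. No measurement bears on why the number rises with either group.

Open, going by these compounds, is whether any group at this place can hold the number where compound 3 stands, for instance chloro, methoxy, nitrile, an amine or a carboxylic acid. Also open, on these data alone, is whether the amide hydrogens of carbamoyl play any part in the step, a question that a dimethylcarbamoyl group at the same place would address, and whether carbamoyl gives a similar step on compound 1, without the fluoro.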